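Adding Bromo to Compound 2: An Estimate for Compound 4

The source may hold more compounds than are shown below. What is called first, only, known or untested is meant among the compounds shown, and "the series" means these compounds.

Three compounds sharing one core were tested in an assay on isolated protein for inhibition of protein deacetylase HDAC6 (Homo sapiens), read by fluorescence, with a stated time of 2 h; a higher number here means a weaker inhibitor, a lower number a stronger inhibitor: compound 1 `CCCNNC(=O)c1ccc(CNC(=O)c2cnc3ccccc3c2)cc1`, compound 2 `CCCNNC(=O)c1ccc(CNC(=O)c2cc3ccccc3[nH]2)cc1` and compound 3 `CCCNNC(=O)c1ccc(CNC(=O)c2nc3ccccc3s2)cc1`. In this assay compound 1 reaches only a limit, > 10000 nM. Compound 2 likewise gives no number but a limit, > 10000 nM. Compound 3 also shows only a limit, > 10000 nM. Compound 2 thus stands where all three stand, at the limit of > 10000 nM in this assay, at which 3 of the 3 values shown sit, and nothing ranks it against the others. Compound 4 `CCCNNC(=O)c1ccc(CNC(=O)c2cc3cc(Br)ccc3[nH]2)cc1` is not yet measured and differs from compound 2 by bromo in place of hydrogen on an aromatic carbon. Among the compounds with values here, with every value at the limit, no measured step gives a size for such a change, and none beyond the scatter is expected. Compound 4 is therefore estimated at 15000 nM, between 4000 nM and 60000 nM. The implied step that the limit leaves unreadable from compound 2 to compound 4 is expected to be slight.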

Compound 4, half-maximal inhibitory concentration: > 10000 nM
Compound 4: a limit, no number; the forecaster's own chance of this, stated with the estimate: 80%; the middle value is on the limit's open side.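

Within the data shown here, compound 2 and compound 4 each give only a limit in this assay, and no step between them can be read. The compounds shown leave open whether bromo in place of hydrogen changes inhibition at all.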